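Furan-3-yl for furan-2-yl on the methyl compound

The source may hold more compounds than are shown below. What is called first, only, known or untested is meant among the compounds shown, and "the series" means these compounds.

Measured in a functional assay on HCT-116 cells (Homo sapiens), read by MTT assay, with a stated time of 72 h; on this read-out lower numbers stand for stronger inhibition and higher numbers for weaker inhibition
Compound 1 `Nc1nc(N)c2c(-c3ccco3)cn([C@@H]3O[C@H](CO)[C@@H](O)[C@H]3O)c2n1` gives > 20000 nM as a limit
Compound 2 `Cc1nc(N)c2c(-c3ccco3)cn([C@@H]3O[C@H](CO)[C@@H](O)[C@H]3O)c2n1` gives > 20000 nM as a limit

Compound 2 stands at > 20000 nM in this assay, which is a limit of the assay and not a number. Going by the values given here, the series so far consists of the limit of > 20000 nM in this assay, at which 2 of the 2 values shown sit, and offers no numerical anchor. Among the compounds with values here, the one measured step is a step that the two limits leave unreadable from compound 1 to compound 2 and it concerns methyl in place of amino on an aromatic carbon, not the furan. No furan exchange has been measured.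

Compound 3 `Cc1nc(N)c2c(-c3ccoc3)cn([C@@H]3O[C@H](CO)[C@@H](O)[C@H]3O)c2n1` follows from compound 2 through furan-3-yl in place of furan-2-yl on an aromatic carbon in which furan-3-yl takes the place of furan-2-yl on an aromatic carbon, with the same atoms joined differently. No step beyond the scatter is expected in this assay in either direction. The expectation rests on compound 2 with its limit of > 20000 nM and on nothing more specific.

Compound 3 is expected near 20000 nM in this read-out, with an estimated range from 6000 nM to 50000 nM for the measurement. The estimated change is a number no higher from compound 2 to compound 3 (the limit leaves the size open) and a report of only a limit is the likeliest expected outcome.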

Compound 3, half-maximal inhibitory concentration: > 20000 nM
Compound 3: a limit, no number (the forecaster's own chance of this, stated with the estimate: 75%); the middle value lies on the limit itself.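

The step from compound 2 to compound 3 cannot be read, as both values are limits of the assay and not numbers. The whole series sits on a single limit: the limit of > 20000 nM in this assay, at which 3 of the 3 values shown sit.

The compounds shown leave open whether furan-3-yl and furan-2-yl differ at all in this assay.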